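Swapping a Hydroxy for a Methyl on a Biphenyl Ether

The source may report more compounds than this note shows. Statements on the series, on what has been measured and on what is new or still open speak of the compounds shown alone.

Of the compounds shown here, three have so far been measured in an assay on CHO cells for displacement of a labelled ligand from Alpha-2C adrenergic receptor (Homo sapiens); on this read-out lower numbers stand for stronger inhibition and higher numbers for weaker inhibition. Compound 1 `CC(Oc1ccccc1-c1ccccc1)C1=NCCO1` gives 5890 nM in this assay, compound 3 `CC(Nc1ccccc1-c1ccccc1)C1=NCCN1` gives 708 nM, and compound 2 `CC(Oc1ccccc1-c1ccc(O)cc1)C1=NCCN1` gives 331 nM. Compound 2 thus shows the lowest number of the three, and its gaps to compound 3 and to compound 1 both lie beyond the usual scatter, so it is the strongest binder among the measured compounds.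

Compound 4 `Cc1ccc(-c2ccccc2OC(C)C2=NCCN2)cc1` has not yet been measured. It differs from compound 2 in a single place: methyl in place of hydroxy on an aromatic carbon. Among the measured compounds shown here, no pair of measured compounds shows what this exchange does on this core, so the expectation rests on general experience with small changes at one aromatic carbon. A modest loss of binding seems most likely, though a result within the scatter cannot be excluded. For compound 4 the estimated step from compound 2 is a 2.1-fold higher number from compound 2 to compound 4 (0.33 log units; beyond the scatter). Compound 4 is therefore expected to give about 700 nM in this assay, with a plausible range from 250 nM to 2000 nM.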

Compound 4, inhibition constant: 251 nM
The estimate for compound 4 lay 2.8-fold (0.45 log units) above the measured number; the range from low to high includes it.
By their numbers in this assay, from the lowest: compounds 4 and 2 (each within the scatter of the next); then compound 3; then compound 1.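

In this assay, replacing hydroxy with methyl on this aromatic carbon gives a 1.3-fold lower number from compound 2 to compound 4 (0.12 log units; within the scatter), so the 4-hydroxyphenyl and 4-methylphenyl compounds cannot be told apart on this read-out. The hydrogen-bond donor and acceptor counted for hydroxy are absent from methyl, yet on this core and at this one place the exchange produces no difference beyond the usual scatter. No measurement available here bears on why the two groups read alike.

Going by these compounds, it remains open whether an amine, a carboxylic acid or a longer chain such as propyl at the same place would also stay within the scatter of compound 2. On these data alone, it is also open whether the same exchange would give a similar step on the core of compound 1 or compound 3.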